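The source may report more compounds than this note shows. Statements on the series, on what has been measured and on what is new or still open speak of the compounds shown alone.

The series is judged in an assay on isolated protein for inhibition of Rho-associated protein kinase 1 (Homo sapiens); a higher number here means a weaker inhibitor, a lower number a stronger inhibitor. Compound 1 `COc1cccc(CNC(=O)c2c[nH]c3cc(-c4cn[nH]c4)ccc23)c1` gives < 1 nM, which is a limit of this assay rather than a number, as the limit of < 1 nM in this assay, at which 1 of the 3 values shown sits, records. Compound 2 `COc1cccc(CNC(=O)c2cn(CCN(C)C)c3cc(-c4cn[nH]c4)ccc23)c1` gives 5 nM in this assay, and the step of an at least 5.0-fold higher number from compound 1 to compound 2 (0.69 log units; beyond the scatter) shows that alkylation at that aromatic nitrogen costs potency. Compound 3 `COc1cccc(CN(C(=O)c2cc3ccc(-c4cn[nH]c4)nc3[nH]2)C2CC2)c1` gives 33 nM, the highest of the two numbers reported; its nearest neighbour is compound 2, whose number is lower by a margin beyond the scatter. Compound 4 `COc1cccc(CN(C)C(=O)c2cc3ccc(-c4cn[nH]c4)nc3[nH]2)c1` differs from compound 3 only by methyl in place of cyclopropyl on an amide-type nitrogen. Going by the values given here, no measured step touches the amide-type nitrogen: the one step in hand concerns an aromatic nitrogen and so offers no guide to the size or direction of this change. With nothing to anchor it, compound 4 is expected to sit close to compound 3, and the step of a 1.2-fold lower number from compound 3 to compound 4 (0.07 log units; within the scatter) is expected to stay within the scatter. The estimate for compound 4 in this assay is therefore 28 nM, with a range from 9 nM to 90 nM.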

Compound 4, half-maximal inhibitory concentration: 27 nM
For compound 4 the middle estimate is 1.0-fold (0.02 log units) above the measured one; low and high end bracket the measured number.
By their numbers in this assay, from the lowest: compound 2; then compounds 4 and 3 (each within the scatter of the next). At a limit, below all of these: compound 1.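

In this assay, going by these compounds alone, the step (a 1.2-fold lower number from compound 3 to compound 4 (0.09 log units; within the scatter)) gives the first reading at the amide-type nitrogen: cyclopropyl, with 3 heavy atoms and a three-membered ring, and methyl, with 1 heavy atom and no ring, cannot be told apart. Between these two groups, then, neither the ring nor the extra carbons register in this assay at this position. Nothing in hand bears on why the two groups read alike.

Still open, from the compounds shown here alone, is whether the amide hydrogen, an ethyl, or a longer chain ending in an amine at this nitrogen would leave the number unchanged in the same way. Also open, going by these compounds, is what a benzyl group would do here, and whether a group with a carboxylic acid would be accommodated at all.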